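This account rests on a few compounds, and the source may have more. Where it says the series, first, only, none or still open, it means among the compounds named here.

Series notes, acylhydrazino-purine ribosides.

In a functional assay on CHO cells for activation of adenosine receptor A2b (Homo sapiens), read by cAMP accumulation (on this read-out lower numbers stand for an effect already at smaller amounts and higher numbers for an effect only at larger amounts of compound), compound 1 `CCNC(=O)[C@H]1O[C@@H](n2cnc3c(NNC(=O)c4cccs4)nc(Cl)nc32)[C@H](O)[C@@H]1O` gives 200 nM and compound 2 `CCNC(=O)[C@H]1O[C@@H](n2cnc3c(NNC(=O)c4sccc4C)nc(Cl)nc32)[C@H](O)[C@@H]1O` gives 340 nM; the methyl-for-hydrogen change reads a 1.7-fold higher number from compound 1 to compound 2 (0.23 log units; within the scatter). Compound 3 `CCNC(=O)[C@H]1O[C@@H](n2cnc3c(NNC(=O)c4cc(C)on4)nc(Cl)nc32)[C@H](O)[C@@H]1O` is reported in this assay only as a limit, > 5000 nM, the reason being (the limit of > 5000 nM in this assay, at which 1 of the 3 values shown sits). The steps onto it, an at least 25-fold higher number from compound 1 to compound 3 (1.39 log units; beyond the scatter) and an at least 14-fold higher number from compound 2 to compound 3 (1.16 log units; beyond the scatter), are both large losses from the thiophene acyl groups to the methyl-oxazole acyl group.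

Compound 4 `CCNC(=O)[C@H]1O[C@@H](n2cnc3c(NNC(=O)c4cc(-c5ccccc5)on4)nc(Cl)nc32)[C@H](O)[C@@H]1O` carries the change (phenyl in place of methyl on an aromatic carbon). Within the data shown here, no measured step replaces methyl by phenyl; the only aromatic-substituent step, from compound 1 to compound 2, stayed within the scatter. With compound 3 at the limit, compound 4 is expected to remain weak. In this assay compound 4 is estimated at 8000 nM, range 1500 nM to 30000 nM. The expected step is a step that the limit leaves unreadable from compound 3 to compound 4.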

Compound 4, half-maximal effective concentration: > 5000 nM
Compound 4 ended at the assay's limit; the forecaster's own chance of this, stated with the estimate: 60%; the middle value does not contradict the limit.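

In this assay the value of compound 4 is a limit and not a number: the limit of > 5000 nM in this assay, at which 2 of the 4 values shown sit.

The thiophene acyl compounds stay clearly apart from it, with an at least 25-fold higher number from compound 1 to compound 4 (1.39 log units; beyond the scatter) and an at least 14-fold higher number from compound 2 to compound 4 (1.16 log units; beyond the scatter), so phenyl on this aromatic carbon, next to the ring oxygen, does not bring the 1,2-oxazol-3-yl series back to their range. The step between the two limits cannot be read, so methyl and phenyl cannot be ranked here.

Open, going by these compounds, is whether hydrogen, an amine or a carboxylic acid on this carbon would give a readable value.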